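The source may hold more compounds than are shown below. What is called first, only, known or untested is meant among the compounds shown, and "the series" means these compounds.

Measured in a functional assay on HCT-116 cells (Homo sapiens), read by MTT assay, with a stated time of 72 h; a lower number here means a stronger inhibitor, a higher number a weaker inhibitor:
- compound 1 `O=c1[nH]cnc2c1c(-c1ccccc1)cn2[C@@H]1O[C@H](CO)[C@@H](O)[C@H]1O`: > 20000 nM
- compound 2 `Nc1nc2c(c(-c3ccsc3)cn2[C@@H]2O[C@H](CO)[C@@H](O)[C@H]2O)c(=O)[nH]1`: > 20000 nM

Neither entry is a true number. Compound 2 gives > 20000 nM, which is a limit of the assay. Going by the values given here, its standing rests only on (the limit of > 20000 nM in this assay, at which 2 of the 2 values shown sit), so no potency can be read from it and no measured step is available to serve as a guide.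

The next compound is compound 3 `Nc1nc2c(c(-c3ccccc3)cn2[C@@H]2O[C@H](CO)[C@@H](O)[C@H]2O)c(=O)[nH]1`. It differs from compound 2 in one place: phenyl in place of thiophen-3-yl on an aromatic carbon.

No step beyond the scatter is expected from this exchange in this assay, in either direction. That expectation rests on compound 2, with its limit of > 20000 nM. It rests also on compound 1, whose limit is > 20000 nM. The expected change is a step that the limit leaves unreadable from compound 2 to compound 3, and a report of only a limit is the likeliest outcome. For compound 3 the estimated value is 25000 nM, with an expected range from 10000 nM to 50000 nM.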

Compound 3, half-maximal inhibitory concentration: > 20000 nM
Compound 3 was reported as a limit; the forecaster's own chance of this, stated with the estimate: 85%; the middle value does not contradict the limit.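

In this assay compound 3 gives > 20000 nM, which is a limit of the assay and not a number. Its steps from compound 1 and from compound 2 therefore cannot be read: the limit of > 20000 nM in this assay, at which 3 of the 3 values shown sit. The compounds shown leave open whether any change on the shared core would give a measurable potency in this assay.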